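This account rests on a few compounds, and the source may have more. Where it says the series, first, only, none or still open, it means among the compounds named here.

Working notes on the hydrazone series. In an assay on CHO-K1 cells for displacement of a labelled ligand from adenosine receptor A1 (Homo sapiens), read by scintillation counting, with a stated time of 60 min (on this read-out higher numbers stand for weaker inhibition and lower numbers for stronger inhibition), compound 1 `Nc1nc(N/N=C/c2ccc(-c3ccccc3)cc2)nc2c1ncn2[C@@H]1O[C@H](CO)[C@@H](O)[C@H]1O` gives 7860 nM, compound 2 `Nc1nc(N/N=C/C2CCCC2)nc2c1ncn2[C@@H]1O[C@H](CO)[C@@H](O)[C@H]1O` gives 5.6 nM and compound 3 `CCCCC/C=C/C=C/C=N/Nc1nc(N)c2ncn([C@@H]3O[C@H](CO)[C@@H](O)[C@H]3O)c2n1` gives 2 nM. On these three numbers compound 3 stands lowest; compound 2 lies nearest and compound 1 furthest, both gaps beyond the scatter. Among the measured compounds shown here, the only single-site step measured is a 2.8-fold lower number from compound 2 to compound 3 (0.45 log units; beyond the scatter), a group of 9 heavy atoms (9 carbon; no ring) in place of a group of 5 heavy atoms (5 carbon; one five-membered non-aromatic ring of carbon only) on the carbon with a double bond to nitrogen.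

Compound 4 `Nc1nc(N/N=C/c2ccc(C(F)(F)F)cc2)nc2c1ncn2[C@@H]1O[C@H](CO)[C@@H](O)[C@H]1O` is not yet measured. Its change from compound 3 is a group of 10 heavy atoms (7 carbon, 3 fluorine; one six-membered aromatic ring of carbon only) in place of a group of 9 heavy atoms (9 carbon; no ring), on a carbon with a double bond to nitrogen. For the measured compounds named here, no measured step covers an aromatic group entering at this carbon, so the bearing of a 2.8-fold lower number from compound 2 to compound 3 (0.45 log units; beyond the scatter) is indirect: it shows that exchanging groups at this carbon moves this assay only modestly when neither group is aromatic. Among the measured compounds the closest structural neighbour of compound 4 is compound 1, which stands at 7860 nM, far from compound 3 at 2 nM. The expected step of a 1000-fold higher number from compound 3 to compound 4 (3.00 log units; beyond the scatter) is therefore toward a much higher number. Compound 4 is estimated at 2000 nM, with a range from 300 nM to 10000 nM.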

Compound 4, inhibition constant: 37 nM
Beside the measured number, compound 4's estimate is 54-fold (1.73 log units) above it; the whole stated range lies above it.
By their numbers in this assay, from the lowest: compound 3; then compound 2; then compound 4; then compound 1.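

Among the compounds shown here, compound 4 is the first aromatic group at the carbon with a double bond to nitrogen to give a low number in this assay, so an aromatic ring at this carbon does not by itself bring a number as high as that of compound 1. The aromatic group still costs something against both non-aromatic groups, with a 19-fold higher number from compound 3 to compound 4 (1.27 log units; beyond the scatter) being large and a 6.6-fold higher number from compound 2 to compound 4 (0.82 log units; beyond the scatter) modest, while a 210-fold lower number from compound 1 to compound 4 (2.33 log units; beyond the scatter) is the largest single-site step measured in this series and shows that the group carried on the aromatic ring, trifluoromethyl in place of phenyl on an aromatic carbon, can move this assay further than the exchange of aromatic for non-aromatic groups does. No measurement at hand accounts for any of these steps.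

Still open, from the compounds shown here alone, is how a plain phenyl, or a methoxy, nitrile, amine or carboxylic acid in place of trifluoromethyl on the same ring, would fall in the wide interval between compound 4 and compound 1. Also open, going by these compounds, is whether a saturated hexyl or octyl chain, or a cyclohexyl ring, at the carbon with a double bond to nitrogen would hold the low numbers of compound 2 and compound 3.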